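Ethyl to tert-Butyl: an Expected Shift in Lipophilicity

The source may hold more compounds than are shown below. What is called first, only, known or untested is meant among the compounds shown, and "the series" means these compounds.

Measured so far in a physicochemical assay for lipophilicity, measured as octanol-water partition; a higher number here means a more lipophilic compound, a lower number a more polar compound:
- compound 1, `O=C(N[C@@H]1O[C@H](CO)[C@@H](O)[C@H](O)[C@H]1O)C1=Cc2cc(Cl)ccc2OC1`, gives -0.169
- compound 2, `CC(C)c1ccc(C[C@H](C)C(=O)N[C@@H]2O[C@H](CO)[C@@H](O)[C@H](O)[C@H]2O)cc1`, gives 0.143
- compound 3, `CCc1ccc(/C=C/C(=O)N[C@@H]2O[C@H](CO)[C@@H](O)[C@H](O)[C@H]2O)cc1`, gives 0.04

All three numbers sit close together. Compound 3 stands second highest of the three, but its gap to compound 2 and its gap to compound 1 both fall within the usual scatter of this assay, so no ordering among them can be claimed.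

Compound 4, `CC(C)(C)c1ccc(/C=C/C(=O)N[C@@H]2O[C@H](CO)[C@@H](O)[C@H](O)[C@H]2O)cc1`, has not yet been measured. It differs from compound 3 in one place: tert-butyl in place of ethyl on an aromatic carbon. Among the compounds with values here, no measured pair shows this exchange, so the expectation rests on the structural change alone, a group of four carbons entering where a group of two carbons leaves. On that basis the step from compound 3 to compound 4 is expected to be upward and beyond the scatter, about a number 0.61 log units higher from compound 3 to compound 4 (beyond the scatter). Compound 4 is therefore estimated at 0.65, within a range of 0.2 to 1.1.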

Compound 4, partition coefficient: 0.496
Compound 4: the middle estimate sits 0.15 log units above what was measured; the measured number falls inside the stated range.
By their numbers in this assay, from the lowest: compounds 1, 3 and 2 (each within the scatter of the next, the first and the last beyond it); then compound 4.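

Within the data shown here, until this pair, no two compounds differed in one place, so this assay had said nothing about any single position. On an aromatic carbon para to a large group, tert-butyl in place of ethyl now gives a number 0.46 log units higher from compound 3 to compound 4 (beyond the scatter) and so shows that the number does respond to a change at this position. The two groups differ in their count of carbon, with neither carrying a hydrogen-bond donor, a hydrogen-bond acceptor or a net charge, and no measurement here explains the size of the step.

From the compounds shown here alone, whether an unbranched butyl chain would give a similar step remains open, as does the effect of an amine or a carboxylic acid at this position. Also open, going by these compounds, is whether the same exchange would give a similar step on the core of compound 1.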